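Moving one trifluoromethyl group: from compound 3 to compound 4

This account rests on a few compounds, and the source may have more. Where it says the series, first, only, none or still open, it means among the compounds named here.

In a functional assay on DU-145 cells (Homo sapiens) for antiproliferative activity, read by propidium iodide staining, with a stated time of 96 h (on this read-out lower numbers stand for stronger inhibition and higher numbers for weaker inhibition), compound 1 `CC(O)(CSc1ccc(C(F)(F)F)cc1)C(=O)Nc1cccc(S(F)(F)(F)(F)F)c1` gives 27200 nM and compound 2 `CC(O)(COc1cccc(S(F)(F)(F)(F)F)c1)C(=O)Nc1ccc(S(F)(F)(F)(F)F)cc1` gives 29600 nM in the same test, while compound 3 `CC(O)(COc1cccc(C(F)(F)F)c1)C(=O)Nc1ccc(S(F)(F)(F)(F)F)cc1` gives 21900 nM there. These three numbers lie within the usual scatter of one another, so compound 3 stands level with the other two.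

Compound 4 `CC(O)(COc1ccccc1C(F)(F)F)C(=O)Nc1ccc(S(F)(F)(F)(F)F)cc1` has the same atoms as compound 3, joined differently: 2-(trifluoromethyl)phenyl in place of 3-(trifluoromethyl)phenyl on an oxygen on a saturated carbon.

For the measured compounds named here, only one measured step changes a single place, and it bears on this change only loosely. It is a 1.4-fold lower number from compound 2 to compound 3 (0.13 log units; within the scatter) and it exchanges one group for another on an aromatic carbon. Going by the values given here, that step stays within the scatter, but no measured step moves a group to another carbon of a ring, so the data offer no direction for this move and only a weak guide to its size. The expected change is a 1.1-fold higher number from compound 3 to compound 4 (0.04 log units; within the scatter) in this assay and so nothing beyond the scatter. For compound 4 the estimated value is 24000 nM with an expected range from 11000 nM to 50000 nM overall.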

Compound 4, half-maximal inhibitory concentration: 7100 nM
Estimate against measurement, compound 4: 3.4-fold (0.53 log units) above; the whole stated range lies above it.
By their numbers in this assay, from the lowest: compound 4; then compounds 3, 1 and 2 (each within the scatter of the next).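

Before this result, the only step between compounds differing in one place, the exchange of one group for another on the ring of compound 2, stayed within the scatter in this assay, so that part of the molecule seemed to tolerate change. Replacing 3-(trifluoromethyl)phenyl with 2-(trifluoromethyl)phenyl on the same oxygen gives a 3.1-fold lower number from compound 3 to compound 4 (0.49 log units; beyond the scatter), a modest step but the first here to clear the scatter, and it comes with no atom gained or lost, which shows that the place of the trifluoromethyl group on this ring can alter the number even when the composition stays the same. Nothing measured here accounts for this step, so its cause remains unknown.

The compounds shown leave open whether this step belongs to the trifluoromethyl group itself or would also appear with another group, as in 2-chlorophenyl or 2-methoxyphenyl, on that oxygen. They also leave open how 4-(trifluoromethyl)phenyl would compare on the same oxygen, and whether 2-(trifluoromethyl)phenyl would give a similar step with a different group in place of the pentafluorosulfanyl group on the amide side.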